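From isopropyl to chloro on the aromatic ring

The compounds below may be only part of what the source reports. "The series", "measured", "known", "first", "only" and "open" are said of these compounds alone.

Of the compounds shown here, three have been measured so far in a functional assay on A549 cells (Homo sapiens) for inhibition, read by colorimetric assay and MTT assay, with a stated time of 72 h; on this read-out higher numbers stand for weaker inhibition and lower numbers for stronger inhibition. Compound 1 `Cn1c2cnc1OCCCCCCCCCCOc1cc3ccccc3cc1-2` gives 20000 nM. Compound 2 `C=CCCCCOc1ncc(-c2ccccc2OC)n1C` gives 5000 nM, and compound 3 `C=CCCCCOc1ncc(-c2cc(C(C)C)ccc2OC)n1C` gives 4000 nM. Compound 3 therefore sits level with compound 2, within the usual scatter of repeat measurements, while compound 1 has a higher number than compound 3, by a gap beyond that scatter.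

The next molecule, compound 4 `C=CCCCCOc1ncc(-c2cc(Cl)ccc2OC)n1C`, differs from compound 3 in one place: chloro in place of isopropyl on an aromatic carbon. That carbon belongs to a six-membered aromatic ring of carbon only, para to a methoxy group.

Within the data shown here, only one measured step bears on this change: a 1.3-fold lower number from compound 2 to compound 3 (0.10 log units; within the scatter), with isopropyl in place of hydrogen on that same carbon. It is a small step, and it stays within the scatter. Among the measured compounds shown here, no compound with chloro has been measured yet, so the evidence is thin. On this basis, no shift beyond the scatter is expected in this assay, in either direction. The estimated step is no change at the digits printed from compound 3 to compound 4 (within the scatter). For compound 4 the expected value is 4000 nM, with an estimated range from 1500 nM to 10000 nM.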

Compound 4, half-maximal inhibitory concentration: 34000 nM
For compound 4 the middle estimate is 8.5-fold (0.93 log units) below the measured one; measured number above the stated range.
By their numbers in this assay, from the lowest: compounds 3 and 2 (each within the scatter of the next); then compounds 1 and 4 (each within the scatter of the next).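

Among these compounds, at this carbon of the aromatic ring, the group does matter in this assay, which the earlier compounds could not show: the only earlier step here, isopropyl in place of hydrogen, gave a 1.3-fold lower number from compound 2 to compound 3 (0.10 log units; within the scatter) and so stayed level. Chloro in place of isopropyl gives an 8.5-fold higher number from compound 3 to compound 4 (0.93 log units; beyond the scatter) and chloro in place of hydrogen gives a 6.8-fold higher number from compound 2 to compound 4 (0.83 log units; beyond the scatter) as well, so both steps, each beyond the scatter, point towards weaker inhibition, and among these three compounds chloro stands apart while hydrogen and isopropyl remain level with each other. Nothing available here shows what lies behind this difference between a single chlorine atom and the other two groups.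

On these data alone, with only hydrogen, isopropyl and chloro seen at this carbon, it remains open whether the loss belongs to chloro alone or would also appear with fluoro, bromo, methyl or methoxy. As far as these compounds go, it is also open whether larger alkyl groups such as tert-butyl, or an amine or a carboxylic acid at the same carbon, would stay level with isopropyl or move the number in either direction.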